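Swapping a 2-chlorophenyl for a 4-iodophenyl

The source may report more compounds than this note shows. Statements on the series, on what has been measured and on what is new or still open speak of the compounds shown alone.

Measured compounds:
- compound 1, `CCCc1cc(N)c2cc(NC(=O)/C=C/c3ccc(C(C)(C)C)cc3)ccc2n1`: 22 nM
- compound 2, `CCCc1cc(N)c2cc(NC(=O)/C=C/c3ccc(Br)cc3)ccc2n1`: 4 nM
- compound 3, `CCCc1cc(N)c2cc(NC(=O)/C=C/c3ccccc3Cl)ccc2n1`: 120 nM

All three share one core and differ only in the ring attached to the double-bonded chain. In an assay on isolated protein for displacement of a labelled ligand from melanin-concentrating hormone receptor 1 (Homo sapiens) (on this read-out higher numbers stand for weaker inhibition and lower numbers for stronger inhibition), compound 3 gives the highest of the three numbers, that is, the weakest binding. Its nearest neighbour is compound 1, and the step of a 30-fold higher number from compound 2 to compound 3 (1.48 log units; beyond the scatter) shows how far it lies from compound 2.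

Compound 4, `CCCc1cc(N)c2cc(NC(=O)/C=C/c3ccc(I)cc3)ccc2n1`, is the next change: 4-iodophenyl in place of 2-chlorophenyl on a double-bonded chain carbon bound to a double-bonded chain carbon. This undoes the move that produced compound 3 and places an iodine where compound 2 carries a bromine. For the measured compounds named here, two measured steps bear on it. The step of a 5.5-fold lower number from compound 1 to compound 2 (0.74 log units; beyond the scatter) showed a modest gain on arriving at a 4-bromophenyl, and the step of a 30-fold higher number from compound 2 to compound 3 (1.48 log units; beyond the scatter) showed a large loss on moving to the 2-chlorophenyl. Returning to a 4-substituted ring in compound 4 is therefore expected to reverse most of that loss, giving a large step downward, a 24-fold lower number from compound 3 to compound 4 (1.38 log units; beyond the scatter), towards the number of compound 2.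

Compound 4 is thus estimated at 5 nM, with a likely range from 2 nM to 15 nM.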

Compound 4, half-maximal inhibitory concentration: 2.3 nM
The estimate for compound 4 lay 2.2-fold (0.34 log units) above the measured number; the range from low to high includes it.
By their numbers in this assay, from the lowest: compounds 4 and 2 (each within the scatter of the next); then compound 1; then compound 3.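

In this assay, replacing 2-chlorophenyl with 4-iodophenyl gives a 52-fold lower number from compound 3 to compound 4 (1.72 log units; beyond the scatter), so this position responds strongly to the ring's substitution, although this single swap changes both the halogen and its place on the ring. Exchanging bromo for iodo gives a 1.7-fold lower number from compound 2 to compound 4 (0.24 log units; within the scatter), so the two halogens cannot be told apart here, while replacing tert-butyl with iodo gives a 9.6-fold lower number from compound 1 to compound 4 (0.98 log units; beyond the scatter), which shows that iodo, like bromo, goes with a clearly lower number than tert-butyl. No supporting measurement is available to explain any of these differences.

A compound carrying 4-chlorophenyl would help to separate the effect of the halogen from that of its place on the ring, since the swap from compound 3 to compound 4 changes both at once. It also remains open whether a halogen is needed at all, as neither 4-methoxyphenyl nor 4-aminophenyl appears among these compounds, and the tert-butyl of compound 1 is the only non-halogen group available for comparison.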